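Trimming the imidazole side chain: from compound 3 to compound 4

The compounds below may be only part of what the source reports. "The series", "measured", "known", "first", "only" and "open" are said of these compounds alone.

Compound 1 `Cc1nc(C)c(CN2CCN(c3cccc4[nH]c(-c5ccc(C(C)(C)C)cc5)nc34)CC2)o1` gives 740 nM in an assay on isolated protein for displacement of a labelled ligand from Gonadotropin-releasing hormone receptor (Rattus norvegicus); on this read-out lower numbers stand for stronger inhibition and higher numbers for weaker inhibition.
Compound 2 `Cc1nc(CN2CCN(c3cccc4[nH]c(-c5ccc(C(C)(C)C)cc5)nc34)CC2)cn1C` gives 34 nM in this assay.
Compound 3 `CCCCc1nc(CN2CCN(c3cccc4[nH]c(-c5ccc(C(C)(C)C)cc5)nc34)CC2)cn1C` gives 58 nM in this assay.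

Compound 3 holds the second highest of the three numbers: a 1.7-fold higher number from compound 2 to compound 3 (0.23 log units; within the scatter), and a 13-fold lower number from compound 1 to compound 3 (1.11 log units; beyond the scatter). Compound 4 `CCn1cc(CN2CCN(c3cccc4[nH]c(-c5ccc(C(C)(C)C)cc5)nc34)CC2)nc1C` differs from compound 3 by 1-ethyl-2-methyl-1H-imidazol-4-yl in place of 2-butyl-1-methyl-1H-imidazol-4-yl on a saturated chain carbon bound to an amine nitrogen in a ring. For the measured compounds named here, two measured steps bear on this. Replacing the oxazole by an imidazole was large: a 22-fold lower number from compound 1 to compound 2 (1.34 log units; beyond the scatter). Exchanging a butyl for a methyl on that imidazole, however, stayed within the scatter: a 1.7-fold higher number from compound 2 to compound 3 (0.23 log units; within the scatter). Compound 4 keeps the imidazole and merely redistributes small chains, so the step of a 1.3-fold lower number from compound 3 to compound 4 (0.11 log units; within the scatter) is expected to fall within the scatter. Compound 4 is therefore estimated at 45 nM, within a range of 18 nM to 120 nM.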

Compound 4, half-maximal inhibitory concentration: 51 nM
For compound 4 the middle estimate is 1.1-fold (0.05 log units) below the measured one, and the stated range covers the measured number.
By their numbers in this assay, from the lowest: compounds 2, 4 and 3 (each within the scatter of the next); then compound 1.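

In this assay, 1-ethyl-2-methyl-1H-imidazol-4-yl in place of 2-butyl-1-methyl-1H-imidazol-4-yl stays within the scatter (a 1.1-fold lower number from compound 3 to compound 4 (0.06 log units; within the scatter)), and so does methyl in place of hydrogen on the chain carbon bound to an aromatic nitrogen (a 1.5-fold higher number from compound 2 to compound 4 (0.18 log units; within the scatter)). The new imidazole also keeps a large gap to the oxazole (a 15-fold lower number from compound 1 to compound 4 (1.16 log units; beyond the scatter)), so compounds 2, 3 and 4 all share this advantage over compound 1. No measured evidence explains these results.

Still open, as far as these compounds go, is whether the imidazole accepts a chain ending in an amine or a carboxylic acid, or a much longer chain.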